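A few compounds are considered here, and "the series" means these few. Any claim that something is new, unique, unknown or untested is made for them only; others in the source may bear on it.

Compounds measured so far:
compound 2, `CC(C)Cn1c(-c2ccc(OCc3c(-c4c(Cl)cccc4Cl)noc3C(C)C)cc2)nc2ccc(C(=O)O)cc21`, 24.7 nM
compound 1, `CC(C)c1onc(-c2c(Cl)cccc2Cl)c1COc1ccc(-c2nc3ccc(C(=O)O)cc3n2Cc2ccc(F)cc2)cc1`, 105 nM

In an assay on isolated protein for agonist activity at Bile acid receptor (Homo sapiens), read by TR-FRET (on this read-out lower numbers stand for an effect already at smaller amounts and higher numbers for an effect only at larger amounts of compound), compound 2 gives the lowest of the two numbers; compound 1 gives 105 nM. Compound 3, `CC(C)c1onc(-c2c(Cl)cccc2Cl)c1COc1ccc(-c2nc3ccc(C(=O)O)cc3n2C(C)C)cc1`, differs from compound 2 by isopropyl in place of isobutyl on an aromatic nitrogen. For the measured compounds named here, the only measured step, a 4.3-fold lower number from compound 1 to compound 2 (0.63 log units; beyond the scatter), changed the same position, but swapped a ring group for a chain, which is a different kind of change from trimming one chain to a shorter one. Going by the values given here, no measured pair shows the present change, so no step beyond the scatter is expected. For compound 3 an expected value is 30 nM, between 12 nM and 80 nM, that is a 1.2-fold higher number from compound 2 to compound 3 (0.08 log units; within the scatter).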

Compound 3, half-maximal effective concentration: 56.7 nM
Compound 3: the middle estimate sits 1.9-fold (0.28 log units) below what was measured; the measured number falls inside the stated range.
By their numbers in this assay, from the lowest: compound 2; then compounds 3 and 1 (each within the scatter of the next).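

Trimming isobutyl to isopropyl on the aromatic nitrogen is not a silent change: it gives a 2.3-fold higher number from compound 2 to compound 3 (0.36 log units; beyond the scatter), so even this small shortening of the chain shows in the read-out. Isopropyl and 4-fluorobenzyl, very different in size and shape, are hardly told apart here (a 1.9-fold lower number from compound 1 to compound 3 (0.27 log units; within the scatter)), which leaves compound 2 alone at the low end among these three. Nothing at hand explains this difference. Open, on these data alone, is whether a longer chain such as n-butyl, or a cyclopropylmethyl group, would match isobutyl or go beyond it.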